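The compounds below may be only part of what the source reports. "The series", "measured", "known", "first", "only" and "open" are said of these compounds alone.

Among the measured compounds shown here, compound 2 `Cc1n[nH]c2ccc(-c3nc4cnc(N5CCN(C)CC5)cn4c3Nc3ccc(F)cc3Br)cc12` gives the lower of the two numbers known so far: in a functional assay on CWR22R cells (Homo sapiens) for inhibition, with a stated time of 120 h, tested at 10 uM (a lower number here means less inhibition, a higher number more inhibition at the concentration tested (going by the name of the read-out)), compound 2 gives 4.41%. Its nearest neighbour is compound 1 `Cc1n[nH]c2ccc(-c3nc4cnc(N5CCN(C)CC5)cn4c3Nc3ccc(Br)cc3)cc12`, which in this assay gives 11.7%; the step of a number 7.3 percentage points lower from compound 1 to compound 2 (within the scatter) lies within the scatter. Compound 3 `Cc1n[nH]c2ccc(-c3nc4cnc(N5CCN(C)CC5)cn4c3Nc3ccc(F)c(Cl)c3)cc12` has not been measured; it differs from compound 2 by 3-chloro-4-fluorophenyl in place of 2-bromo-4-fluorophenyl on a nitrogen on an aromatic ring. For the measured compounds named here, the only step that bears on this change, the one from compound 1 to compound 2, also swapped the halogen pattern on the same phenyl and stayed within the scatter, so no step beyond the scatter is expected here: the estimated step is a number 3.6 percentage points higher from compound 2 to compound 3 (within the scatter). Compound 3 is therefore expected to give 8% in this assay, within -5% to 22%.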

Compound 3, a percentage reported as inhibition, at one concentration (the size of the read-out at that concentration, not a potency): 0.82%
The estimate for compound 3 lay 7.2 percentage points above the measured number, and the stated range covers the measured number.
By their numbers in this assay, from the lowest: compounds 3, 2 and 1 (each within the scatter of the next, the first and the last beyond it).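

In this assay the 3-chloro-4-fluorophenyl group on this nitrogen can be read against two other aryl groups. Against 2-bromo-4-fluorophenyl the change gives no clear shift (a number 3.6 percentage points lower from compound 2 to compound 3 (within the scatter)), but against 4-bromophenyl it gives the first step at this position to leave the scatter (a number 10.9 percentage points lower from compound 1 to compound 3 (beyond the scatter)). No measurement at hand explains that step. The compounds shown leave open how an amine or a carboxylic acid on this phenyl, or a cyclohexyl group in its place, would read in this assay at this position.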